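The compounds below may be only part of what the source reports. "The series", "measured", "known", "first", "only" and "open" are said of these compounds alone.

Of the compounds shown here, three that share one core have been measured in an assay on FRT-Jurkat cells for inhibition of nuclear factor NF-kappa-B complex (Homo sapiens), read by flow cytometry, with a stated time of 24 h, tested at 10 uM; a higher number here means more inhibition at the concentration tested (going by the name of the read-out), a lower number less inhibition. Compound 1, `Cc1ccccc1Nc1ccc2c(c1)C(=O)N(C1CCC(=O)NC1=O)C2=O`, gives 2% in this assay. Compound 2, `CC(C)(C)c1ccc(Nc2ccc3c(c2)C(=O)N(C2CCC(=O)NC2=O)C3=O)cc1`, gives 17%, and compound 3, `CCCCCc1ccc(Nc2ccc3c(c2)C(=O)N(C2CCC(=O)NC2=O)C3=O)cc1`, gives 12%. Compound 3 stands second highest of the three numbers, but its gap to compound 2 and its gap to compound 1 both lie within the scatter, so no order among them can be claimed. Going by the values given here, the only measured step that alters the group on the aromatic carbon, a number 5 percentage points lower from compound 2 to compound 3 (within the scatter), stayed within the scatter; the step of a number 15 percentage points higher from compound 1 to compound 2 (beyond the scatter) exchanges the whole aryl group and bears less directly on the present change. Compound 4, `O=C1CCC(N2C(=O)c3ccc(Nc4ccccc4)cc3C2=O)C(=O)N1`, carries hydrogen in place of pentyl on an aromatic carbon. Given the step of a number 5 percentage points lower from compound 2 to compound 3 (within the scatter), which did not leave the scatter, compound 4 is expected to show no step beyond the scatter, a number 4 percentage points lower from compound 3 to compound 4 (within the scatter). Compound 4 is therefore estimated at 8%, within a range from 0% to 20%.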

Compound 4, a percentage reported as inhibition, at one concentration (the size of the read-out at that concentration, not a potency): 6%
Compound 4: the middle estimate sits 2 percentage points above what was measured; low and high end bracket the measured number.
By their numbers in this assay, from the lowest: compounds 1, 4, 3 and 2 (each within the scatter of the next, the first and the last beyond it).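

In this assay, hydrogen on this aromatic carbon gives a number 6 percentage points lower from compound 3 to compound 4 (within the scatter) and so cannot be told apart from pentyl, but the same change gives a number 11 percentage points lower from compound 2 to compound 4 (beyond the scatter) when tert-butyl leaves, a modest step that does separate the two groups. Hydrogen in place of methyl gives a number 4 percentage points higher from compound 1 to compound 4 (within the scatter) and so adds no separation, which leaves the tert-butyl comparison as the only one of the three to pass the scatter. No independent measurement is available to explain these differences.

From the compounds shown here alone, whether an amine, a carboxylic acid or a chain longer than pentyl on this aromatic carbon would reach beyond compound 2 remains open. Going by these compounds, it is also open whether a smaller branched group, such as isopropyl, would stand with tert-butyl or with hydrogen.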